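Stepwise chain shortening toward compound 3

The compounds below may be only part of what the source reports. "The series", "measured", "known", "first", "only" and "open" are said of these compounds alone.

Measured in a functional assay on the whole organism for inhibition, with Mus musculus as the target, read by paw edema, with a stated time of 180 min, at a dose of 200 mg/kg by the oral route; on this read-out lower numbers stand for a weaker effect and higher numbers for a stronger effect at the one dose given:
compound 1 `CCCn1c(Cn2c(=O)oc3ccc(C)cc32)n[nH]c1=S`: 44.3%
compound 2 `CCn1c(Cn2c(=O)oc3ccc(C)cc32)n[nH]c1=S`: 31.8%

Among the measured compounds shown here, compound 2 holds the lower of the two numbers in this assay; the single measured step, a number 12.5 percentage points lower from compound 1 to compound 2 (beyond the scatter), is the only comparison at hand. Compound 3 `Cc1ccc2oc(=O)n(Cc3n[nH]c(=S)n3C)c2c1` differs from compound 2 by hydrogen in place of methyl on a saturated chain carbon bound to an aromatic nitrogen. That is the same kind of change taken one bond further in, so the earlier step is the one that bears on it. Continuing in the same direction, a further fall of similar size is expected, a number 11.8 percentage points lower from compound 2 to compound 3 (beyond the scatter). For compound 3 the estimate in this assay is 20%, expected to lie between 8% and 32%.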

Compound 3, a percentage reported as inhibition, in the whole organism at one dose (the size of the read-out at that dose, not a potency): 38.6%
Compound 3: middle estimate off by 18.6 percentage points, on the low side, and the stated range ends below it.
By their numbers in this assay, from the lowest: compounds 2, 3 and 1 (each within the scatter of the next, the first and the last beyond it).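

In this assay, the shortening does not continue as a steady fall: a number 6.8 percentage points higher from compound 2 to compound 3 (within the scatter), and a number 5.7 percentage points lower from compound 1 to compound 3 (within the scatter). Compound 3 therefore cannot be told apart from compound 2 or compound 1, and a number 12.5 percentage points lower from compound 1 to compound 2 (beyond the scatter) stands as an isolated difference, not a trend along the chain. No measured evidence bears on this result.

Still open, as far as these compounds go, is whether a longer chain such as butyl, or an ethyl chain carrying an amine or a carboxylic acid, would separate from these compounds at this place.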